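Tert-butyl in place of methyl on an aromatic carbon

The source may hold more compounds than are shown below. What is called first, only, known or untested is meant among the compounds shown, and "the series" means these compounds.

For the measured compounds named here, in a functional assay on HCT-116 cells (Homo sapiens) for inhibition, read by MTT assay, with a stated time of 48 h (on this read-out lower numbers stand for stronger inhibition and higher numbers for weaker inhibition), compound 2 `Cc1ccc(C/N=C2\NC(=O)/C(=C3\CCNC(=O)c4[nH]ccc43)S2)cc1` gives 4760 nM as the only actual number so far. Compound 1 `O=C1N/C(=N\Cc2ccc(C(F)(F)F)cc2)S/C1=C1/CCNC(=O)c2[nH]ccc21` gives > 100000 nM in this assay and this is a limit, not a number. Methyl in place of trifluoromethyl on an aromatic carbon produced an at least 21-fold lower number from compound 1 to compound 2 (1.32 log units; beyond the scatter) in this assay and the size of that step rests on the limit of > 100000 nM in this assay, at which 1 of the 2 values shown sits, rather than on two numbers.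

Compound 3 `CC(C)(C)c1ccc(C/N=C2\NC(=O)/C(=C3\CCNC(=O)c4[nH]ccc43)S2)cc1` carries tert-butyl in place of methyl on that same aromatic carbon (tert-butyl in place of methyl on an aromatic carbon) of a six-membered aromatic ring of carbon only. Just one measured step bears on this change, the large one from compound 1 to compound 2 (an at least 21-fold lower number from compound 1 to compound 2 (1.32 log units; beyond the scatter)) which shows that the read-out can respond strongly to the group at this carbon. It says nothing directly about tert-butyl, so only a moderate rise in the number is expected. The expected change is a 3.2-fold higher number from compound 2 to compound 3 (0.50 log units; beyond the scatter) in this assay and it may well exceed the scatter. For compound 3 the estimated value is 15000 nM with an expected range from 4000 nM to 70000 nM in this assay as the read-out.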

Compound 3, half-maximal inhibitory concentration: > 100000 nM
Compound 3 gave a limit, no number; the forecaster's own chance of this, stated with the estimate: 20%; middle value at least 6.6-fold (0.82 log units) away from the limit.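

In this assay the step of an at least 21-fold higher number from compound 2 to compound 3 (1.32 log units; beyond the scatter) shows that the gain seen with methyl does not carry over to every alkyl group at this carbon, so methyl is the only one of the three groups shown that gives a number. Compound 3 gives > 100000 nM, which is a limit and not a number. Compound 1 also stands at a limit, so trifluoromethyl and tert-butyl cannot be ranked against each other and the step between compound 1 and compound 3 cannot be read: the limit of > 100000 nM in this assay, at which 2 of the 3 values shown sit.

On these data alone, it remains open how the number behaves with other alkyl groups on this aromatic carbon, such as ethyl or isopropyl, or with plain hydrogen there in place of any group. Also open, as far as these compounds go, is whether an amine, a hydroxyl group or a carboxylic acid at this carbon would give a number in this assay at all, or would sit at the limit as tert-butyl and trifluoromethyl do.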